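A few compounds are considered here, and "the series" means these few. Any claim that something is new, unique, unknown or untested is made for them only; others in the source may bear on it.

Compound 2 `COc1cc(OC)c(/C=C/S(=O)(=O)Cc2ccc(OC)c(N)c2)c(OC)c1` stands lowest of the two numbers recorded in a functional assay on DU-145 cells (Homo sapiens) for cytotoxicity, read by trypan blue exclusion, with a stated time of 96 h (a lower number here means a stronger inhibitor, a higher number a weaker inhibitor), where compound 2 gives 4 nM. Going by the values given here, its nearest neighbour, compound 1 `COc1ccc(CS(=O)(=O)/C=C/c2c(OC)cccc2OC)cc1N`, gives 50 nM in this assay; the only measured step, a 13-fold lower number from compound 1 to compound 2 (1.10 log units; beyond the scatter), is a methoxy in place of hydrogen on an aromatic carbon and lies beyond the scatter. Compound 3 `COC(=O)CCNc1cc(CS(=O)(=O)/C=C/c2c(OC)cc(OC)cc2OC)ccc1OC` differs from compound 2 by 2-(methoxycarbonyl)ethyl in place of hydrogen on a nitrogen on an aromatic ring. Among the compounds with values here, no measured step touches this nitrogen, so the methoxy step from compound 1 to compound 2 bears on it only as a sign that the shared core tolerates change of this size without collapse. With nothing to anchor the direction, a step expected to be modest and toward a higher number seems the safer reading, as a 3.0-fold higher number from compound 2 to compound 3 (0.48 log units; beyond the scatter). Compound 3 is therefore estimated at 12 nM, within 3 nM to 50 nM, in this assay.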

Compound 3, half-maximal inhibitory concentration: 1500 nM
The estimate for compound 3 lay 130-fold (2.10 log units) below the measured number; the measured number lies above the stated range.
By their numbers in this assay, from the lowest: compound 2; then compound 1; then compound 3.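

Going by these compounds alone, this is the first measured change on the nitrogen of the aromatic amino group, and it shows that this position is far from indifferent to substitution: in this assay, placing 2-(methoxycarbonyl)ethyl on it gives a 380-fold higher number from compound 2 to compound 3 (2.57 log units; beyond the scatter). The methoxy step on the aromatic carbon showed only how the number moves at another place on the shared core, whereas this result shows that the free amino group of compound 2 cannot be exchanged for this chain without a large rise in the number. No measurement shown here explains the size of this rise.

With a single substituent on this nitrogen, the compounds shown leave open whether the rise follows from the chain as a whole or from its methyl ester. A methyl group, an acetyl group or a 2-carboxyethyl group on the same nitrogen would separate these readings.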